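From methylamino to dimethylamino on the ethynyl compound

The source may report more compounds than this note shows. Statements on the series, on what has been measured and on what is new or still open speak of the compounds shown alone.

Measured in a functional assay on HepG2 cells (Homo sapiens) for antiproliferative activity, read by XTT assay, with a stated time of 72 h; on this read-out lower numbers stand for stronger inhibition and higher numbers for weaker inhibition:
Compound 1 `CNc1ncnc2c1c(-c1ccco1)cn2[C@@H]1O[C@H](CO)[C@@H](O)[C@H]1O` gives 850 nM
Compound 2 `CNc1ncnc2c1c(-c1ccccc1)cn2[C@@H]1O[C@H](CO)[C@@H](O)[C@H]1O` gives > 20000 nM as a limit
Compound 3 `C#Cc1cn([C@@H]2O[C@H](CO)[C@@H](O)[C@H]2O)c2ncnc(NC)c12` gives > 15000 nM as a limit

Compound 3 stands at > 15000 nM in this assay and this is a limit of the assay, not a number. Its place relative to compound 1 is still clear, with an at least 17-fold higher number from compound 1 to compound 3 (1.24 log units; beyond the scatter) on record.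

Compound 4 `C#Cc1cn([C@@H]2O[C@H](CO)[C@@H](O)[C@H]2O)c2ncnc(N(C)C)c12` differs from compound 3 by methyl in place of hydrogen on a nitrogen on an aromatic ring, methylamino to dimethylamino: methyl in place of hydrogen on a nitrogen on an aromatic ring.

Going by the values given here, no measured step touches that nitrogen. All of them change the group on an aromatic carbon, where an at least 23-fold higher number from compound 1 to compound 2 (1.37 log units; beyond the scatter) was large, as was the step to compound 3, while a step that the two limits leave unreadable from compound 2 to compound 3 cannot be read. Compound 4 keeps the ethynyl group of compound 3, so no step beyond the scatter is expected, and another limit is likely.

The expected result is a step that the limit leaves unreadable from compound 3 to compound 4 as an estimate. For compound 4 the estimated value is 20000 nM with an expected range of 8000 nM to 40000 nM in this assay.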

Compound 4, half-maximal inhibitory concentration: 1320 nM
For compound 4 the middle estimate is 15-fold (1.18 log units) above the measured one, outside the stated range (below it).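

In this assay, the nitrogen on the aromatic ring proves to be a second place where one small change moves the read-out: with the ethynyl group kept, a single added methyl gives an at least 11-fold lower number from compound 3 to compound 4 (1.05 log units; beyond the scatter). Every earlier readable step had changed the group on an aromatic carbon, so the ethynyl group does not by itself hold a compound at the limit of the assay. The true size of this step stays open on one side, because compound 3 carries a limit and not a number: the limit of > 15000 nM in this assay, at which 1 of the 4 values shown sits.

The compounds shown leave open whether this effect belongs to methyl alone or would hold for ethyl or a pyrrolidine ring on that nitrogen. Going by these compounds, it is also open whether dimethylamino would give a similar step with furan-2-yl or phenyl in place of ethynyl.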